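Replacing a Methoxy with Pyridin-2-yl on the Shared Core

The compounds below may be only part of what the source reports. "The series", "measured", "known", "first", "only" and "open" are said of these compounds alone.

For the measured compounds named here, compound 1 `COc1ccc2c(c1)CN(C(=O)c1cc(S(C)(=O)=O)ccc1O[C@@H](C)C(F)(F)F)C2` gives the higher of the two numbers measured so far in an assay on CHO cells for inhibition of sodium- and chloride-dependent glycine transporter 1 (Homo sapiens), read by scintillation counting (a higher number here means that more compound is needed for the effect, a lower number that less compound is needed), at 180 nM. Compound 2 `C[C@H](Oc1ccc(S(C)(=O)=O)cc1C(=O)N1Cc2cc(C(F)(F)F)cnc2C1)C(F)(F)F`, built on a different core, gives 50 nM in this assay, a gap beyond the usual scatter. Compound 3 `C[C@H](Oc1ccc(S(C)(=O)=O)cc1C(=O)N1Cc2ccc(-c3ccccn3)cc2C1)C(F)(F)F` differs from compound 1 by pyridin-2-yl in place of methoxy on an aromatic carbon. Going by the values given here, no measured pair shows this kind of change, so the expectation rests on little: a moderate move toward a lower number is expected, a 2.6-fold lower number from compound 1 to compound 3 (0.41 log units; beyond the scatter). For compound 3 the estimated value in this assay is 70 nM, within a range from 18 nM to 280 nM.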

Compound 3, half-maximal effective concentration: 84 nM
Compound 3: middle estimate off by 1.2-fold (0.08 log units), on the low side; low and high end bracket the measured number.
By their numbers in this assay, from the lowest: compounds 2 and 3 (each within the scatter of the next); then compound 1.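

This position on the shared core accepts a whole aromatic ring: in this assay pyridin-2-yl in place of methoxy gives a 2.1-fold lower number from compound 1 to compound 3 (0.33 log units; beyond the scatter) and so the number goes down, not up, with the added ring. For the compounds shown here, this is the first step here that changes one place only. No measurement at hand explains the shift. As far as these compounds go, whether the ring nitrogen matters stays open, as a plain phenyl ring on this carbon would be needed to tell. How a nitrile or an amine would behave at the same place is also unknown.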